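The source may report more compounds than this note shows. Statements on the series, on what has been measured and on what is new or still open speak of the compounds shown alone.

Measured so far in a functional assay on DLD-1 cells (Homo sapiens) for cytotoxicity, with a stated time of 48 h; on this read-out lower numbers stand for stronger inhibition and higher numbers for weaker inhibition:
compound 1 `CCCC(=O)Oc1ccc2oc(/C=C/[S+](C)[O-])cc(=O)c2c1` - 8700 nM
compound 2 `C[S+]([O-])/C=C/c1cc(=O)c2cc(Cl)ccc2o1` - 6500 nM

Compound 2, at 6500 nM, cannot be separated from compound 1 on these two numbers. Going by the values given here, the one measured step is a 1.3-fold lower number from compound 1 to compound 2 (0.13 log units; within the scatter), with chloro in place of (propylcarbonyl)oxy on an aromatic carbon.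

Compound 3 `C[S+]([O-])/C=C/c1cc(=O)c2cc(Br)ccc2o1` differs from compound 2 in one place: bromo in place of chloro on an aromatic carbon. In words, this is bromo in place of chloro on an aromatic carbon of a six-membered aromatic ring of carbon only.

The only guide is the small change between compound 1 and compound 2, shown by a 1.3-fold lower number from compound 1 to compound 2 (0.13 log units; within the scatter), so no shift beyond the scatter is expected in this assay and no direction is favoured. The expected change is a 1.1-fold lower number from compound 2 to compound 3 (0.03 log units; within the scatter). The estimate for compound 3 is 6000 nM, with an expected range from 3000 nM to 12000 nM.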

Compound 3, half-maximal inhibitory concentration: 4500 nM
Beside the measured number, compound 3's estimate is 1.3-fold (0.12 log units) above it; measured number inside the range.
By their numbers in this assay, from the lowest: compounds 3, 2 and 1 (each within the scatter of the next).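

In this assay, bromo in place of chloro on this aromatic carbon gives a 1.4-fold lower number from compound 2 to compound 3 (0.16 log units; within the scatter) and so adds a second halogen that cannot be separated from the first. Bromo in place of (propylcarbonyl)oxy gives a 1.9-fold lower number from compound 1 to compound 3 (0.29 log units; within the scatter) and thus extends the earlier comparison: the chloro, bromo and (propylcarbonyl)oxy compounds remain within the scatter of one another at this position, so no preference among these three groups can be read. No available evidence bears on this result.

From the compounds shown here alone, it remains open whether an amine, a carboxylic acid or a plain hydrogen on this carbon would give a step beyond the scatter. Whether a longer ester chain or a methoxy group would stay among these three numbers is also unresolved.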